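Swapping 4-fluorophenyl for 3-bromophenyl in compound 3

The compounds below may be only part of what the source reports. "The series", "measured", "known", "first", "only" and "open" are said of these compounds alone.

In a functional assay (mast cells) for inhibition, with Rattus norvegicus as the target (on this read-out higher numbers stand for an effect only at larger amounts of compound and lower numbers for an effect already at smaller amounts), compound 1 `O=C(O)c1cnc2n(c1=O)CCC/C2=N\Nc1ccccc1` gives 2900 nM and compound 2 `CC1CCn2c(ncc(C(=O)O)c2=O)/C1=N/Nc1ccccc1` gives 5400 nM. Compound 3 `CC1CC/C(=N\Nc2ccc(F)cc2)c2ncc(C(=O)O)c(=O)n21` has the lowest number of the three (1200 nM) and both others lie beyond the scatter from it. Compound 4 `CC1CC/C(=N\Nc2cccc(Br)c2)c2ncc(C(=O)O)c(=O)n21` has 3-bromophenyl in place of 4-fluorophenyl on an amine nitrogen. Among the compounds with values here, the only measured single change (a 1.9-fold higher number from compound 1 to compound 2 (0.27 log units; within the scatter)) is a methyl swap on a ring carbon, not a change of this group, so it offers no direct guide. Within the data shown here, with no measured precedent, the starting point in this assay is compound 3 at 1200 nM. No step beyond the scatter is expected from that starting point. The expected step is small (a 1.3-fold higher number from compound 3 to compound 4 (0.10 log units; within the scatter)). For compound 4 the estimated value is 1500 nM with an expected range from 500 nM to 4500 nM (a deliberately wide span).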

Compound 4, half-maximal effective concentration: 6700 nM
Compound 4: middle estimate off by 4.5-fold (0.65 log units), on the low side; measured number above the stated range.
By their numbers in this assay, from the lowest: compound 3; then compounds 1, 2 and 4 (each within the scatter of the next, the first and the last beyond it).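

In this assay, putting 3-bromophenyl in place of 4-fluorophenyl on an amine nitrogen gives a 5.6-fold higher number from compound 3 to compound 4 (0.75 log units; beyond the scatter) and lies beyond the scatter, whereas the methyl change gave only a 1.9-fold higher number from compound 1 to compound 2 (0.27 log units; within the scatter) and stayed within it. The group on this nitrogen therefore affects the read-out, although both groups have the same heavy-atom count and neither has hydrogen-bond donors or acceptors. No available evidence explains this step. The halogen and its place on the ring change together, so their contributions remain unseparated. A 4-bromophenyl or 3-fluorophenyl group would tell them apart.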